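This account rests on a few compounds, and the source may have more. Where it says the series, first, only, none or still open, it means among the compounds named here.

Going by the values given here, compound 1 `Cc1ccc2[nH]c(-c3cn(-c4ccccc4)nc3-c3ccccc3)nc2c1` gives the highest of the two numbers so far in a functional assay on A549 cells (Homo sapiens) for antiproliferative activity, read by MTT assay, with a stated time of 48 h (a higher number here means a weaker inhibitor, a lower number a stronger inhibitor), at 3610 nM. Among the compounds with values here, compound 2 `COc1ccc2[nH]c(-c3cn(-c4ccccc4)nc3-c3ccccc3)nc2c1` gives 1230 nM, and the only measured step, a 2.9-fold lower number from compound 1 to compound 2 (0.47 log units; beyond the scatter), brings in the same methoxy group that compound 3 carries. Compound 3 `COc1ccc(-c2nn(-c3ccccc3)cc2-c2nc3cc(C)ccc3[nH]2)cc1` differs from compound 1 by methoxy in place of hydrogen on an aromatic carbon, methoxy entering in place of hydrogen rather than methyl. The measured step bears only loosely on this change, so a downward step in this assay of similar or smaller size, a 1.8-fold lower number from compound 1 to compound 3 (0.26 log units; within the scatter), is expected. Compound 3 is estimated at 2000 nM, between 700 nM and 6000 nM.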

Compound 3, half-maximal inhibitory concentration: 5070 nM
Beside the measured number, compound 3's estimate is 2.5-fold (0.40 log units) below it; the measured number falls inside the stated range.
By their numbers in this assay, from the lowest: compound 2; then compounds 1 and 3 (each within the scatter of the next).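

In this assay, phenyl to 4-methoxyphenyl gives a 1.4-fold higher number from compound 1 to compound 3 (0.15 log units; within the scatter), so methoxy para to a large group leaves compound 3 inside the scatter of compound 1. The step seen with methoxy in place of methyl, a 2.9-fold lower number from compound 1 to compound 2 (0.47 log units; beyond the scatter), therefore does not carry over to this place. Nothing on hand accounts for this difference between the two places.

Still open, from the compounds shown here alone, is whether an amine, a carboxylic acid or a longer alkoxy chain at this place would move the number beyond the scatter of compound 1.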